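The source may report more compounds than this note shows. Statements on the series, on what has been measured and on what is new or still open speak of the compounds shown alone.

Compound 1 `COC(=O)c1ccc2ccc(C(=O)c3ccccc3)c-2cc1` in an assay on cells for displacement of a labelled ligand from Orexin receptor type 2 (Homo sapiens), read by scintillation counting, with stated times of 10 min and 90 min, tested at 10 uM; a lower number here means less inhibition, a higher number more inhibition at the concentration tested (going by the name of the read-out): compound 1 gives 28.9%.
Compound 2 `NC(=O)c1ccc2ccc(C(=O)c3ccccc3)c-2cc1` in this assay: compound 2 gives 18%.

Within the data shown here, compound 2 stands lowest of the two numbers; the single measured step leading to it is a number 10.9 percentage points lower from compound 1 to compound 2 (beyond the scatter). Compound 3 `COC(=O)Cc1ccc2ccc(C(=O)c3ccccc3)c-2cc1` differs from compound 2 by (methoxycarbonyl)methyl in place of carbamoyl on an aromatic carbon. Among the measured compounds shown here, this change restores an ester while adding a chain, so the only measured step that bears on it is a number 10.9 percentage points lower from compound 1 to compound 2 (beyond the scatter), a modest lowering that would now run the other way. Compound 3 is therefore expected to show a modest rise a number 7 percentage points higher from compound 2 to compound 3 (within the scatter) in this assay. The estimate for compound 3 is 25%, with a range from 5% to 45%.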

Compound 3, a percentage reported as inhibition, at one concentration (the size of the read-out at that concentration, not a potency): -4.3%
For compound 3 the middle estimate is 29.3 percentage points above the measured one; the measured number lies below the stated range.
By their numbers in this assay, from the lowest: compound 3; then compound 2; then compound 1.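

On this aromatic carbon of the seven-membered ring, (methoxycarbonyl)methyl in place of carbamoyl gives a number 22.3 percentage points lower from compound 2 to compound 3 (beyond the scatter) in this assay, and the same group in place of methoxycarbonyl gives a number 33.2 percentage points lower from compound 1 to compound 3 (beyond the scatter) in the same assay. An ester alone therefore does not bring the number back: compound 3 keeps a methyl ester, yet it stands lowest of the three. Nothing available explains this fall. Going by these compounds, whether a carboxylic acid, an amine or a longer chain at this carbon would raise the number remains open, as does the effect of a primary amide at the end of the same chain.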